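The source may report more compounds than this note shows. Statements on the series, on what has been measured and on what is new or still open speak of the compounds shown alone.

Compound 1 `CCC(=O)N1CCN(Cc2nc3ccccc3n2Cc2cccc(C)c2)CC1` gives the highest number of the three measured compounds in an assay on isolated protein for inhibition of aldehyde dehydrogenase 1A1 (Homo sapiens), read by spectrophotometry, tested at 10 uM (a higher number here means more inhibition at the concentration tested (going by the name of the read-out), a lower number less inhibition), where compound 1 gives 85.1%. Compound 2 `O=C(C1CC1)N1CCN(Cc2nc3ccccc3n2Cc2ccccc2F)CC1` gives 40.7% in this assay, and compound 3 `O=C(C1CC1)N1CCN(Cc2nc3ccccc3n2Cc2ccc(Cl)cc2)CC1` gives 56.6%. Among the compounds with values here, the one single-change step among them, a number 15.9 percentage points higher from compound 2 to compound 3 (beyond the scatter), concerns the group on the saturated chain carbon bound to an aromatic nitrogen, not the amide end of the shared core.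

Compound 4 `CCc1ccc(C(=O)N2CCN(Cc3nc4ccccc4n3Cc3cccc(C)c3)CC2)cc1` differs from compound 1 at that amide end: 4-ethylphenyl in place of ethyl on a carbonyl carbon. Cut one bond further out, the change reads propanoyl to (4-ethylphenyl)carbonyl. Within the data shown here, no measured step touches this position, so nothing here indicates how this assay responds to a six-membered aromatic ring of carbon only replacing a two-carbon chain on the carbonyl carbon. With compound 1 already high, the expected step of a number 13.1 percentage points lower from compound 1 to compound 4 (beyond the scatter) is a modest decrease or none beyond the scatter. Compound 4 is therefore expected to give about 72%, within a range from 40% to 95%.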

Compound 4, a percentage reported as inhibition, at one concentration (the size of the read-out at that concentration, not a potency): 67%
Compound 4: middle estimate off by 5 percentage points, on the high side, and the stated range covers the measured number.
By their numbers in this assay, from the lowest: compound 2; then compound 3; then compound 4; then compound 1.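

Within the data shown here, this is the first measured change at the amide end of the shared core: in this assay, putting 4-ethylphenyl in place of ethyl on a carbonyl carbon brings a number 18.1 percentage points lower from compound 1 to compound 4 (beyond the scatter). The position therefore accepts a group of 8 heavy atoms with a six-membered aromatic ring of carbon only, and compound 4 still gives 67%, though the change does lower the number. Nothing available gives a reason for this drop.

Going by these compounds, whether the lower number comes from the ring itself or from the ethyl group on it stays open, as does how a plain phenyl, a longer chain such as butyl, or an amine would read on that carbonyl carbon. Also open, on these data alone, is whether the step would keep its size with a different group on the saturated chain carbon bound to an aromatic nitrogen.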